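Heteroaryl amide swap on a shared core

The compounds below may be only part of what the source reports. "The series", "measured", "known", "first", "only" and "open" are said of these compounds alone.

Compound 1 `CCCCCCCCCCCC[C@@H](O)[C@H]1CC[C@H]([C@H](O)CCCCCCCCCCNC(=O)c2ccnn2C)O1` gives 52.5 nM in a functional assay on NCI-H23 cells (Homo sapiens) for inhibition, read by colorimetric assay and sulforhodamine B assay, with a stated time of 48 h; on this read-out higher numbers stand for weaker inhibition of growth and lower numbers for stronger inhibition of growth. Compound 2 `CCCCCCCCCCCC[C@@H](O)[C@H]1CC[C@H]([C@H](O)CCCCCCCCCCNC(=O)c2cccs2)O1` gives 676 nM in the same assay.

Among the measured compounds shown here, compound 2 stands with the highest number of the two measured compounds, its only neighbour being compound 1, which lies well below it. For the measured compounds named here, the one measured step, a 13-fold higher number from compound 1 to compound 2 (1.11 log units; beyond the scatter), shows that exchanging the heteroaryl group on the carbonyl carbon can move the read-out a long way.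

Compound 3 `CCCCCCCCCCCC[C@@H](O)[C@H]1CC[C@H]([C@H](O)CCCCCCCCCCNC(=O)c2ccoc2)O1` has not yet been measured. Its change from compound 2 is furan-3-yl in place of thiophen-2-yl on a carbonyl carbon. Going by the values given here, no measured step covers this particular exchange; the step from compound 1 to compound 2 concerns a different pair of heteroaryl groups and only indicates that such swaps need not stay within the scatter. Without a closer precedent, the expected step of a 1.5-fold lower number from compound 2 to compound 3 (0.18 log units; within the scatter) is treated as uncertain in direction, with a wide range. Compound 3 is therefore estimated at 450 nM, within 100 nM to 2000 nM.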

Compound 3, concentration for 50% growth inhibition: 3020 nM
Estimate against measurement, compound 3: 6.7-fold (0.83 log units) below, outside the stated range (above it).
By their numbers in this assay, from the lowest: compound 1; then compound 2; then compound 3.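

In this assay, furan-3-yl in place of thiophen-2-yl on the carbonyl carbon gives a 4.5-fold higher number from compound 2 to compound 3 (0.65 log units; beyond the scatter), so the read-out moves beyond the scatter even between two five-membered aromatic rings that each carry one hetero atom and match in their counted hydrogen-bond donors and acceptors. Measured against 1-methyl-1H-pyrazol-5-yl, the same furan-3-yl gives a 58-fold higher number from compound 1 to compound 3 (1.76 log units; beyond the scatter), a wider gap than the earlier step from the thiophen-2-yl amide, and all three amides now stand apart beyond the scatter, with compound 1 lowest and compound 3 highest. Nothing measured here accounts for this order, which stands only as an observation.

The exchange changes both the hetero atom, sulfur to oxygen, and the ring numbering in the group's name, so the three compounds cannot show which of the two carries the step, a question that furan-2-yl or thiophen-3-yl on the same carbonyl carbon would address. On these data alone, it also stays open whether the low number of compound 1 depends on the methyl group of its ring, as 1H-pyrazol-5-yl would test, or whether a plain phenyl ring would fall anywhere in this order.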